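A few compounds are considered here, and "the series" means these few. Any claim that something is new, unique, unknown or untested is made for them only; others in the source may bear on it.

Working notes on the series of lipopeptide-type compounds.

The series shares one core, a di-acylated thioglycerol cysteine amide, and varies the group on the amide nitrogen. Compound 1 `CCCCCCCCCCCC(=O)OC[C@H](CSC[C@@H](N)C(=O)NC(C)(C)CO)OC(=O)CCCCCCCCCCC` carries 1-(hydroxymethyl)-1-methylethyl there and in an assay on HEK293 cells for agonist activity at Toll-like receptor 2 (Homo sapiens) (on this read-out higher numbers stand for an effect only at larger amounts of compound and lower numbers for an effect already at smaller amounts), compound 1 gives 15500 nM. Compound 2 `CCCCCCCCCCCC(=O)OC[C@H](CSC[C@@H](N)C(=O)N[C@H](C)CO)OC(=O)CCCCCCCCCCC` carries 1-(hydroxymethyl)ethyl and in this assay compound 2 gives 22200 nM; the step of a 1.4-fold higher number from compound 1 to compound 2 (0.16 log units; within the scatter). Compound 3 `CCCCCCCCCCCC(=O)OC[C@H](CSC[C@@H](N)C(=O)NCCCS(=O)(=O)O)OC(=O)CCCCCCCCCCC` carries 3-sulfopropyl and in this assay compound 3 gives 5560 nM, the lowest of the three numbers: a 2.8-fold lower number from compound 1 to compound 3 (0.45 log units; beyond the scatter) and a 4.0-fold lower number from compound 2 to compound 3 (0.60 log units; beyond the scatter).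

Compound 4 `CCCCCCCCCCCC(=O)OC[C@H](CSC[C@@H](N)C(=O)NC(C)CCC(C)C)OC(=O)CCCCCCCCCCC` is not yet measured. The change (1,4-dimethylpentyl in place of 3-sulfopropyl on an amide-type nitrogen). All three measured steps concern the same nitrogen, so all bear on it. The two hydroxy-bearing groups sat within the scatter of each other, and the 3-sulfopropyl group moved the number modestly lower. Going by the values given here, no measured compound carries a group with neither donor nor acceptor, so the direction rests on the expectation that the modest gain seen in compound 3 (5560 nM) is given back. Compound 4 is therefore estimated at 18000 nM in this assay, within 7000 nM to 45000 nM, meaning an expected step of a 3.2-fold higher number from compound 3 to compound 4 (0.51 log units; beyond the scatter).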

Compound 4, half-maximal effective concentration: 190 nM
Compound 4: the middle estimate sits 95-fold (1.98 log units) above what was measured; the whole stated range lies above it.
By their numbers in this assay, from the lowest: compound 4; then compound 3; then compounds 1 and 2 (each within the scatter of the next).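

Going by these compounds alone, at this amide-type nitrogen the number can move much further than the earlier compounds showed: their steps were within the scatter or modest, whereas 1,4-dimethylpentyl, the only group here with no hydrogen-bond donors or acceptors, gives the lowest number in this assay and large steps from all three, namely (a 29-fold lower number from compound 3 to compound 4 (1.47 log units; beyond the scatter)), (a 120-fold lower number from compound 2 to compound 4 (2.07 log units; beyond the scatter)) and (an 82-fold lower number from compound 1 to compound 4 (1.91 log units; beyond the scatter)). The earlier ranking of the three polar-substituted compounds therefore covers only a small part of the range this position can span. Nothing available explains why the number falls so far.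

One compound cannot separate the contribution of the branching from that of the chain itself. A straight hexyl chain, a longer chain such as decyl, a cyclohexyl ring, or an amine or carboxylic acid at the end of a similar chain would each test that.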